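Swapping the Aryl Ketone: What to Expect for Compound 4

A few compounds are considered here, and "the series" means these few. Any claim that something is new, unique, unknown or untested is made for them only; others in the source may bear on it.

Three compounds have been measured in a functional assay on HepG2 cells (Homo sapiens) for cytotoxicity, read by MTT assay, with a stated time of 48 h; on this read-out higher numbers stand for weaker inhibition and lower numbers for stronger inhibition:
compound 1 `COc1cc(-c2nnc3n2NC(c2ccco2)C(C(=O)c2ccc(Br)cc2)S3)cc(OC)c1OC` gives > 100000 nM, which is an assay limit rather than a number
compound 2 `COc1cc(-c2nnc3n2NC(c2cccs2)C(C(=O)c2ccc(F)cc2)S3)cc(OC)c1OC` gives 54200 nM
compound 3 `COc1cc(C(=O)C2Sc3nnc(-c4cc(OC)c(OC)c(OC)c4)n3NC2c2cccs2)cc(OC)c1OC` gives > 100000 nM, which is an assay limit rather than a number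

Compound 1 therefore stands at the limit of > 100000 nM in this assay, at which 2 of the 3 values shown sit; no number is known for it, only that limit.

Compound 4 `COc1cc(-c2nnc3n2NC(c2ccco2)C(C(=O)c2cccc4ccccc24)S3)cc(OC)c1OC` differs from compound 1 in one place: naphthalen-1-yl in place of 4-bromophenyl on a carbonyl carbon. For the measured compounds named here, the only measured step that also changes the group on the carbonyl carbon is an at least 1.8-fold higher number from compound 2 to compound 3 (0.26 log units; that floor lies within the scatter), where the value of compound 3 is a limit. That step, and the limit of compound 1, give no sign that a different aryl group on the carbonyl carbon lowers the number in this assay.

For compound 4 the step of a number no higher from compound 1 to compound 4 (the limit leaves the size open) is expected to be none beyond the scatter. Compound 4 is thus estimated at 100000 nM, within a range from 40000 nM to 300000 nM, most likely reported again as a limit.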

Compound 4, half-maximal inhibitory concentration: 33900 nM
Estimate against measurement, compound 4: 2.9-fold (0.47 log units) above; measured number below the stated range.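

Naphthalen-1-yl in place of 4-bromophenyl on the carbonyl carbon gives an at least 2.9-fold lower number from compound 1 to compound 4 (0.46 log units; beyond the scatter) in this assay. This shows that a change at this position can lower the number, which the earlier step from the 4-fluorophenyl compound to the 3,4,5-trimethoxyphenyl compound did not show. The full size of the step stays open, since compound 1 has only an assay limit and no number: the limit of > 100000 nM in this assay, at which 2 of the 4 values shown sit.

The compounds shown leave open how a plain phenyl, a 4-aminophenyl or a naphthalen-2-yl group on this carbonyl carbon would read, so it cannot be told whether the second aromatic ring or the absence of bromine matters more. They also leave open whether naphthalen-1-yl would lower the number on the core of compound 2.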